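A few compounds are considered here, and "the series" means these few. Any claim that something is new, unique, unknown or untested is made for them only; others in the source may bear on it.

Measured compounds:
compound 1 `CC(C)CCC(=O)Nc1c(C(O)(C(F)(F)F)C(F)(F)F)ccc2ccccc12` gives 49 nM in an assay on LtK cells with ATP-sensitive inward rectifier potassium channel 11 (Homo sapiens) as the target; a higher number here means that more compound is needed for the effect, a lower number that less compound is needed;
compound 2 `O=C(Nc1c(C(O)(C(F)(F)F)C(F)(F)F)ccc2ccccc12)C1CCCC1` gives 495 nM in this assay.

Going by the values given here, compound 1 holds the lowest of the two numbers, with compound 2 the only neighbour at a 10-fold higher number from compound 1 to compound 2 (1.00 log units; beyond the scatter). Compound 3 `Cc1cccc(C(=O)Nc2c(C(O)(C(F)(F)F)C(F)(F)F)ccc3ccccc23)c1` differs from compound 1 as follows: 3-methylphenyl in place of isopentyl on a carbonyl carbon. Among the compounds with values here, the one measured step that bears on this place, a 10-fold higher number from compound 1 to compound 2 (1.00 log units; beyond the scatter), moved the number upward when a ring replaced the isopentyl chain, so a step in the same direction is expected here, estimated at a 4.1-fold higher number from compound 1 to compound 3 (0.61 log units; beyond the scatter). Compound 3 is therefore estimated at 200 nM, within 50 nM to 800 nM.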

Compound 3, half-maximal effective concentration: 23 nM
Beside the measured number, compound 3's estimate is 8.7-fold (0.94 log units) above it; the measured number lies below the stated range.
By their numbers in this assay, from the lowest: compound 3; then compound 1; then compound 2.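

Putting 3-methylphenyl on the carbonyl carbon brought a 2.1-fold lower number from compound 1 to compound 3 (0.33 log units; beyond the scatter) in this assay, so a ring at this position does not by itself raise the number. Replacing cyclopentyl with 3-methylphenyl gave a 22-fold lower number from compound 2 to compound 3 (1.33 log units; beyond the scatter) here, showing that which ring sits at this position matters more than whether one does. No measurement at hand accounts for this difference between the two rings.

On these data alone, the share of the methyl group in this result remains open. So does the place that a plain phenyl, a pyridine or a longer chain would take at this position.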